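Mirror Image of Compound 1 at the Bile Acid Receptor

The source may hold more compounds than are shown below. What is called first, only, known or untested is meant among the compounds shown, and "the series" means these compounds.

Measured so far:
compound 1, `O=C(O)c1cccc([C@H]2C[C@@H](c3ccc(OCc4c(-c5c(Cl)cccc5Cl)noc4C4CC4)cc3Cl)C2)c1`: 99%
compound 2, `CO[C@]1(c2ccc(OCc3c(-c4c(Cl)cccc4Cl)noc3C3CC3)cc2Cl)C[C@H](c2cccc(C(=O)O)c2)C1`: 93%

In an assay on isolated protein for agonist activity at Bile acid receptor (Homo sapiens), read by FRET (a lower number here means a smaller maximal response, a higher number a larger maximal response), compound 1 stands at 99% and compound 2 at 93%, the two within the scatter of each other, as the step of a number 6 percentage points lower from compound 1 to compound 2 (within the scatter) shows. Compound 3, `O=C(O)c1cccc([C@H]2C[C@H](c3ccc(OCc4c(-c5c(Cl)cccc5Cl)noc4C4CC4)cc3Cl)C2)c1`, is not yet measured. It differs from compound 1 in that (the two compounds have the same atoms and bonds and differ only in configuration as drawn: 2 of 2 stereo elements differ (all stereocentres are inverted: mirror images); a stereocentre at a saturated ring carbon is drawn s in compound 1 and r in compound 3; a stereocentre at a saturated ring carbon is drawn s in compound 1 and r in compound 3). Within the data shown here, no measured step bears on such an inversion; the only step known concerns a methoxy group, not configuration. The expected step in this assay is therefore uncertain, with a downward direction judged more likely: a number 39 percentage points lower from compound 1 to compound 3 (beyond the scatter). Compound 3 is estimated at 60%, ranging from 10% to 100%.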

Compound 3, largest response reached (reported as efficacy), in percent of the reference or control that the assay uses: 100%
The estimate for compound 3 lay 40 percentage points below the measured number, within the range that was stated.
By their numbers in this assay, from the lowest: compounds 2, 1 and 3 (each within the scatter of the next).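

Inverting both stereocentres at the saturated ring carbons gives a number 1 percentage points higher from compound 1 to compound 3 (within the scatter) in this assay. Compound 2 had shown only that a methoxy group can be added at one of these carbons; this step shows that the largest response reached also does not separate the two configurations. Configuration is the only variable in this comparison: the fact that compounds 1 and 3 differ only in the configuration as drawn

The compounds shown leave open how much of each compound is needed to reach that response. They also leave open whether configuration would remain without consequence with an amide in place of the carboxylic acid.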